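A few compounds are considered here, and "the series" means these few. Any claim that something is new, unique, unknown or untested is made for them only; others in the source may bear on it.

Of the compounds shown here, three built on the same core have been tested in a functional assay on HeLa cells (Homo sapiens) for inhibition, read by MTT assay, with a stated time of 48 h; on this read-out higher numbers stand for weaker inhibition and lower numbers for stronger inhibition. Compound 1 `Brc1ccc2[nH]cc(C(c3ccccc3)c3c[nH]c4ccc(Br)cc34)c2c1` gives 900 nM. Compound 2 `Oc1ccc(C(c2c[nH]c3ccc(Br)cc23)c2c[nH]c3ccc(Br)cc23)cc1` gives 4000 nM, and compound 3 `Clc1ccc(C(c2c[nH]c3ccc(Br)cc23)c2c[nH]c3ccc(Br)cc23)cc1` gives 4800 nM. On these numbers compound 2 stands second highest of the three: its nearest neighbour is compound 3, since a 1.2-fold higher number from compound 2 to compound 3 (0.08 log units; within the scatter), while compound 1 lies furthest away, as a 4.4-fold higher number from compound 1 to compound 2 (0.65 log units; beyond the scatter).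

Compound 4 `Brc1ccc(C(c2c[nH]c3ccc(Br)cc23)c2c[nH]c3ccc(Br)cc23)cc1` differs from compound 2 in a single place: bromo in place of hydroxy on an aromatic carbon. Going by the values given here, three measured steps bear on this change. Putting hydroxy onto the bare ring of compound 1 gave a 4.4-fold higher number from compound 1 to compound 2 (0.65 log units; beyond the scatter), and putting chloro in the same spot gave a 5.3-fold higher number from compound 1 to compound 3 (0.73 log units; beyond the scatter), so both substituents weakened inhibition to a similar, modest degree. Exchanging one for the other, a 1.2-fold higher number from compound 2 to compound 3 (0.08 log units; within the scatter), made no difference beyond the scatter. Bromo, like chloro, is a halogen entering the position where hydroxy left, so the swap in compound 4 is expected to behave like the step from compound 2 to compound 3.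

Compound 4 is therefore expected to show a 1.1-fold higher number from compound 2 to compound 4 (0.05 log units; within the scatter), a change within the scatter. The estimate for compound 4 in this assay is 4500 nM, with a likely range from 2000 nM to 10000 nM.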

Compound 4, half-maximal inhibitory concentration: 1500 nM
The estimate for compound 4 lay 3.0-fold (0.48 log units) above the measured number, outside the stated range (below it).
By their numbers in this assay, from the lowest: compounds 1 and 4 (each within the scatter of the next); then compounds 2 and 3 (each within the scatter of the next).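

At this spot on the ring, para to a large group, the two halogens do not behave alike in this assay: bromo in place of chloro gives a 3.2-fold lower number from compound 3 to compound 4 (0.51 log units; beyond the scatter), and bromo in place of hydroxy gives a 2.7-fold lower number from compound 2 to compound 4 (0.43 log units; beyond the scatter), so the match between hydroxy and chloro does not extend to every group placed here. Bromo in place of hydrogen gives a 1.7-fold higher number from compound 1 to compound 4 (0.22 log units; within the scatter), which leaves compound 4 within the scatter of compound 1, the compound with the bare ring. The earlier steps shown here suggested that any group at this spot costs some inhibition, yet bromo, unlike hydroxy in compound 2 and chloro in compound 3, shows no such cost.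

With only hydrogen, hydroxy, chloro and bromo shown here, it remains open whether an amine, a carboxylic acid or a longer chain at this spot would sit with compounds 1 and 4 or with compounds 2 and 3. Nothing available here explains why bromo and chloro part ways.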